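Amide replacement in a cytotoxicity series: working notes

The source may hold more compounds than are shown below. What is called first, only, known or untested is meant among the compounds shown, and "the series" means these compounds.

Measured so far:
compound 1, `COc1cc(-c2nn(-c3cccc(NC(=O)Nc4ccc(Cl)c(Cl)c4)c3)cc2-c2ccncc2)ccc1Cl`: in a functional assay on HCT-15 cells (Homo sapiens) for inhibition, read by sulforhodamine B assay, with a stated time of 48 h (on this read-out lower numbers stand for higher toxicity in this test and higher numbers for lower toxicity in this test), compound 1 gives > 50000 nM, which is a limit of the assay.
compound 2, `COc1cc(-c2nn(-c3cccc(NC(=O)Nc4ccc(Cl)c(C(F)(F)F)c4)c3)cc2-c2ccncc2)ccc1Cl`: in this assay compound 2 gives > 32500 nM, which is also a limit.

Compound 2 stands only at a limit in this assay, namely (the limit of > 32500 nM in this assay, at which 1 of the 2 values shown sits), and no number for it is known. Compound 1 likewise sits at the limit (the limit of > 50000 nM in this assay, at which 1 of the 2 values shown sits). Within the data shown here, the single measured step, a step that the two limits leave unreadable from compound 1 to compound 2, is therefore unreadable in both size and direction.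

Compound 3, `COc1cc(-c2nn(-c3cccc(NC(=O)c4ccccc4)c3)cc2-c2ccncc2)ccc1Cl`, is not yet measured in this assay. It differs from compound 2 by phenyl in place of (4-chloro-3-(trifluoromethyl)phenyl)amino on a carbonyl carbon. Among the measured compounds shown here, no measured step bears on this change: the one step known, trifluoromethyl in place of chloro on an aromatic carbon, is left unreadable by its two limits. For the measured compounds named here, no size or direction of step in this assay can thus be drawn from the measured data; the only guide is that both measured compounds sit at limits.

Compound 3 is expected to give about 40000 nM in this assay, with a range from 8000 nM to 100000 nM. The step this estimate implies, a step that the limit leaves unreadable from compound 2 to compound 3, is an expectation only and cannot be set against any readable measured step.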

Compound 3, concentration lethal to 50% of the cells: > 100000 nM
Compound 3 was reported as a limit; the forecaster's own chance of this, stated with the estimate: 65%; middle value at least 2.5-fold (0.39 log units) away from the limit.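

Compound 3 is reported in this assay only as a limit, > 100000 nM. Compound 1 and compound 2 also stand at limits, so neither step to compound 3 can be read in size or direction. The compounds shown leave open what actual value any of the three has in this assay, and so what either replacement on the carbonyl carbon does.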